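The compounds below may be only part of what the source reports. "The series", "measured", "known", "first", "only" and "open" are said of these compounds alone.

Measured so far in a functional assay on the whole organism (Tail, strain ICR) with Mus musculus as the target, in the tail flick test, with a stated time of 30 min, at a dose of 25 umol/kg by the oral route; on this read-out higher numbers stand for a stronger effect at the one dose given and lower numbers for a weaker effect:
compound 1 `O=C(CN(c1nc(Cl)nc2[nH]cnc12)C1CC1)N[C@@H](CO)C(=O)OCc1ccccc1` gives 31.9%
compound 2 `C[C@H](NC(=O)CN(c1nc(Cl)nc2[nH]cnc12)C1CC1)C(=O)OCc1ccccc1` gives 41.2%
compound 3 `CC[C@H](C)[C@H](NC(=O)CN(c1nc(Cl)nc2[nH]cnc12)C1CC1)C(=O)OCc1ccccc1` gives 41.4%

Compound 3 holds the highest of the three numbers in this assay, but the spread is narrow: a number 0.2 percentage points higher from compound 2 to compound 3 (within the scatter) and a number 9.5 percentage points higher from compound 1 to compound 3 (within the scatter), so the three compounds cannot be separated on these data. All three share the core and the benzyl ester; they differ only in the group on the saturated chain carbon bound to an amide-type nitrogen and a carbonyl carbon.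

Compound 4 `NC(=O)C[C@H](NC(=O)CN(c1nc(Cl)nc2[nH]cnc12)C1CC1)C(=O)OCc1ccccc1` is not yet measured. It differs from compound 3 as follows: carbamoylmethyl in place of sec-butyl on a saturated chain carbon bound to an amide-type nitrogen and a carbonyl carbon.

Of the measured steps, the one bearing most directly on this change is the exchange of hydroxymethyl for sec-butyl at the same place, which gave a number 9.5 percentage points higher from compound 1 to compound 3 (within the scatter). The step of a number 9.3 percentage points higher from compound 1 to compound 2 (within the scatter) points the same way, and a number 0.2 percentage points higher from compound 2 to compound 3 (within the scatter) is flat. Among the compounds with values here, since every change at this position so far has stayed within the scatter, no step beyond the scatter is expected here either; if anything, compound 1, which carries a hydroxymethyl at this place, gives 31.9% and suggests a slightly lower number for compound 4.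

Compound 4 is therefore expected to give about 34% in this assay, within 20% to 48%. The expected step is a number 7.4 percentage points lower from compound 3 to compound 4 (within the scatter).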

Compound 4, a percentage reported as activity, at one dose (the size of the read-out at that dose, not a potency): 24.4%
Beside the measured number, compound 4's estimate is 9.6 percentage points above it; low and high end bracket the measured number.
By their numbers in this assay, from the lowest: compounds 4, 1, 2 and 3 (each within the scatter of the next, the first and the last beyond it).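

In this assay, within the data shown here, this position now shows steps beyond the scatter for the first time: carbamoylmethyl in place of sec-butyl gives a number 17 percentage points lower from compound 3 to compound 4 (beyond the scatter), and the comparison with the methyl group of compound 2 gives a number 16.8 percentage points lower from compound 2 to compound 4 (beyond the scatter), so the place on the saturated chain carbon bound to an amide-type nitrogen and a carbonyl carbon is not indifferent to the group it carries. Carbamoyl in place of hydroxy, by contrast, gives a number 7.5 percentage points lower from compound 1 to compound 4 (within the scatter), so compound 1 and compound 4 cannot be separated, and compound 1 also stays within the scatter of compound 2 and compound 3, which leaves a graded spread rather than two clean groups. Nothing available gives a reason for the lower number of compound 4.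

As far as these compounds go, how a carboxylic acid, an amine or a longer carbamoylethyl chain on the same carbon would read in this assay remains open, and with it whether the loss belongs to the carbamoyl group itself or to replacing sec-butyl more generally. From the compounds shown here alone, all four numbers come from one oral dose and one time, with the benzyl ester and the shared core held constant, so potency and the effect of another ester also remain open.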